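A Bromofuran Chalcone Weighed Against a Thiophene Limit

This account rests on a few compounds, and the source may have more. Where it says the series, first, only, none or still open, it means among the compounds named here.

Compound 1 `COc1ccc(OC)c(C(=O)/C=C/c2cccs2)c1` is known in a functional assay on cells (Neutrophil, Rattus norvegicus) for inhibition (a higher number here means a weaker inhibitor, a lower number a stronger inhibitor), only by a limit; compound 1 gives > 30000 nM. Compound 2 `COc1ccc(OC)c(C(=O)/C=C/c2ccc(C)o2)c1` gives 22200 nM in this assay. The step of an at least 1.3-fold lower number from compound 1 to compound 2 (0.13 log units; that floor lies within the scatter) rests on the limit of > 30000 nM in this assay, at which 1 of the 2 values shown sits, and so sets only a floor. Compound 3 `COc1ccc(OC)c(C(=O)/C=C/c2occc2Br)c1` differs from compound 1 by 3-bromofuran-2-yl in place of thiophen-2-yl on a double-bonded chain carbon bound to a double-bonded chain carbon. Going by the values given here, the one measured step, thiophen-2-yl to 5-methylfuran-2-yl, was small, so no step beyond the scatter is expected, and the estimated step is a number no higher from compound 1 to compound 3 (the limit leaves the size open). Compound 3 is expected to give 30000 nM, within 15000 nM to 60000 nM.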

Compound 3, half-maximal inhibitory concentration: > 30000 nM
Compound 3: a limit, no number (the forecaster's own chance of this, stated with the estimate: 50%); the middle value sits exactly at the limit.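

Putting 3-bromofuran-2-yl in place of thiophen-2-yl on this double-bonded chain carbon gives no readable change in this assay, as the steps resting on two limits cannot be read. Against 5-methylfuran-2-yl, the change gives an at least 1.3-fold higher number from compound 2 to compound 3 (0.13 log units; that floor lies within the scatter), so this comparison yields only a floor. What can be read at this place remains bounded: the limit of > 30000 nM in this assay, at which 2 of the 3 values shown sit.

On these data alone, whether an amine or a carboxylic acid on the five-membered aromatic ring would give a value clear of that limit stays open.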